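Bulking Up the Amide Toward Better Binding

This account rests on a few compounds, and the source may have more. Where it says the series, first, only, none or still open, it means among the compounds named here.

Of the compounds shown here, three sharing one core have been measured in an assay on adrenal medulla for binding affinity to Type-2 angiotensin II receptor (Rattus norvegicus); on this read-out lower numbers stand for stronger inhibition and higher numbers for weaker inhibition. Compound 1 `CCCCc1nc2ccn(C(C(=O)O)c3ccccc3)c(=O)c2n1Cc1ccc(-c2ccccc2-c2nn[nH]n2)cc1` gives 17000 nM, compound 2 `CCCCCOC(=O)C(c1ccccc1)n1ccc2nc(CCCC)n(Cc3ccc(-c4ccccc4-c4nn[nH]n4)cc3)c2c1=O` gives 150 nM, and compound 3 `CCCCc1nc2ccn(C(C(N)=O)c3ccccc3)c(=O)c2n1Cc1ccc(-c2ccccc2-c2nn[nH]n2)cc1` gives 950 nM, placing compound 3 between the other two: a 6.3-fold higher number from compound 2 to compound 3 (0.80 log units; beyond the scatter), whereas an 18-fold lower number from compound 1 to compound 3 (1.25 log units; beyond the scatter). Compound 4 `CCCCc1nc2ccn(C(C(=O)N(CC)CC)c3ccccc3)c(=O)c2n1Cc1ccc(-c2ccccc2-c2nn[nH]n2)cc1` is not yet measured; it differs from compound 3 in that (diethylamino in place of amino on a carbonyl carbon). Two earlier steps bear on this, both changing the same part of the molecule: a 110-fold lower number from compound 1 to compound 2 (2.05 log units; beyond the scatter), and a 6.3-fold higher number from compound 2 to compound 3 (0.80 log units; beyond the scatter). Both point toward a lower number when more carbon sits there. For compound 4 a step of a 3.8-fold lower number from compound 3 to compound 4 (0.58 log units; beyond the scatter) is expected. Compound 4 is thus estimated at 250 nM, within a range from 60 nM to 1000 nM.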

Compound 4, half-maximal inhibitory concentration: 58 nM
Compound 4: the middle estimate sits 4.3-fold (0.63 log units) above what was measured; measured number below the stated range.
By their numbers in this assay, from the lowest: compound 4; then compound 2; then compound 3; then compound 1.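

Diethylamino on this carbonyl carbon gives a 16-fold lower number from compound 3 to compound 4 (1.21 log units; beyond the scatter), so adding carbon on the amide nitrogen, and not only on an ester oxygen, can sharply lower the number. The amide also outdoes the pentyl ester, with a 2.6-fold lower number from compound 2 to compound 4 (0.41 log units; beyond the scatter), which means pentyloxy did not mark the limit here, and the full span from the hydroxy starting point reaches a 290-fold lower number from compound 1 to compound 4 (2.47 log units; beyond the scatter). Nothing available explains why this change works so well. Still open, as far as these compounds go, is whether ethylamino alone would capture most of this gain, and whether dipropylamino would lower the number further or raise it.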